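Swapping the methoxyphenyl urea for a cyclohexyl urea

A few compounds are considered here, and "the series" means these few. Any claim that something is new, unique, unknown or untested is made for them only; others in the source may bear on it.

Three ureas on a shared core have been measured in a functional assay on Shh Light II cells (Mus musculus) for inhibition, read by a luciferase reporter; a higher number here means a weaker inhibitor, a lower number a stronger inhibitor. Compound 1 `O=C(NCC1CCC1)N1CCC(c2nc(-c3ccc4ccccc4n3)no2)CC1` gives 410 nM. Compound 2 `N#Cc1ccccc1NC(=O)N1CCC(c2nc(-c3ccc4ccccc4n3)no2)CC1` gives 190 nM. Compound 3 `COc1ccccc1N(C)C(=O)N1CCC(c2nc(-c3ccc4ccccc4n3)no2)CC1` gives 3100 nM, the highest of the three numbers, and both steps to it are beyond the scatter: a 16-fold higher number from compound 2 to compound 3 (1.21 log units; beyond the scatter) and a 7.6-fold higher number from compound 1 to compound 3 (0.88 log units; beyond the scatter). Compound 4 `O=C(NC1CCCCC1)N1CCC(c2nc(-c3ccc4ccccc4n3)no2)CC1` differs from compound 3 in one place: cyclohexylamino in place of (2-methoxyphenyl)(methyl)amino on a carbonyl carbon. The step from compound 1 to compound 3 is this same kind of exchange run in reverse, with cyclobutylmethylamino rather than cyclohexylamino as the aliphatic partner. Compound 4 is therefore expected to return a clearly lower number, a 6.2-fold lower number from compound 3 to compound 4 (0.79 log units; beyond the scatter). The estimate for compound 4 in this assay is 500 nM, with a range from 180 nM to 1500 nM.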

Compound 4, half-maximal inhibitory concentration: 57 nM
Compound 4: the middle estimate sits 8.8-fold (0.94 log units) above what was measured; the measured number lies below the stated range.
By their numbers in this assay, from the lowest: compound 4; then compound 2; then compound 1; then compound 3.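

In this assay, cyclohexylamino gives the lowest number of the four ureas: a 54-fold lower number from compound 3 to compound 4 (1.74 log units; beyond the scatter), a 3.3-fold lower number from compound 2 to compound 4 (0.52 log units; beyond the scatter) and a 7.2-fold lower number from compound 1 to compound 4 (0.86 log units; beyond the scatter). On this carbonyl carbon, then, an aromatic ring is not needed for a low number, since the non-aromatic ring of compound 4 goes beyond both 2-cyanophenyl and cyclobutylmethyl. Nothing available explains these steps.

The step from compound 3 changes the ring and the hydrogen-bond donor count together, leaving their contributions unseparated. Going by these compounds, whether cyclohexyl(methyl)amino or cyclopentylamino would keep this low number remains open.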